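Methyl in Place of Hydrogen on a Sulfonyl Aryl Ring

The compounds below may be only part of what the source reports. "The series", "measured", "known", "first", "only" and "open" are said of these compounds alone.

Of the compounds shown here, two have been measured. Compound 1, `Cc1ccc(S(=O)(=O)N2CC(O)C[C@H]2C(=O)Nc2ccc(C(=O)O)cc2)cc1`, carries a hydroxyl group on its pyrrolidine ring and a methyl group on the aryl sulfonamide. In a functional assay on the whole organism for inhibition, with Rattus norvegicus as the target, read by paw edema, with stated times of 1 h and 2 h, at a dose of 100 mg/kg by the oral route (a lower number here means less inhibition, a higher number more inhibition at the dose given (going by the name of the read-out)), compound 1 gives 67.2%. Compound 2, `O=C(O)c1ccc(NC(=O)[C@@H]2CCCN2S(=O)(=O)c2ccccc2)cc1`, lacks both groups, and in this assay compound 2 gives 29.4%. Of the two numbers shown, compound 2 stands lowest, with compound 1 a number well above it, beyond the scatter. For the measured compounds named here, the two compounds differ in two places at once, so no single-change step links them.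

Compound 3, `Cc1ccc(S(=O)(=O)N2CCC[C@H]2C(=O)Nc2ccc(C(=O)O)cc2)cc1`, is the unmeasured compound. It differs from compound 2 in one place: methyl in place of hydrogen on an aromatic carbon. Put one bond further out, the change reads phenyl to 4-methylphenyl. How much of the gap between compound 1 and compound 2 belongs to this methyl group alone cannot be read from two compounds, since the hydroxyl group changes as well.

The step from compound 2 to compound 3 is expected to be a modest gain in this assay, a number 12.6 percentage points higher from compound 2 to compound 3 (beyond the scatter), rather than none at all. Compound 3 is therefore estimated at 42%, within a range of 22% to 62%.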

Compound 3, a percentage reported as inhibition, in the whole organism at one dose (the size of the read-out at that dose, not a potency): 36.3%
The estimate for compound 3 lay 5.7 percentage points above the measured number, and the stated range covers the measured number.
By their numbers in this assay, from the lowest: compounds 2 and 3 (each within the scatter of the next); then compound 1.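

In this assay, methyl in place of hydrogen on an aromatic carbon, para to a large group, now has a size of its own (a number 6.9 percentage points higher from compound 2 to compound 3 (within the scatter)), so in this pair the change from phenyl to 4-methylphenyl cannot be told apart from no change at all. Hydrogen in place of hydroxy on a saturated ring carbon is a different matter (a number 30.9 percentage points lower from compound 1 to compound 3 (beyond the scatter)), and of the two single changes now shown, it alone lies beyond the scatter. The data shown offer no reason for the size of either step.

As far as these compounds go, whether another group on the same aromatic carbon, such as chloro, methoxy or an amine, would stay as close to the hydrogen compound as methyl does remains open, as does whether the step from hydrogen to methyl would be the same size on a core that keeps the hydroxyl group. It is also open whether the large step belongs to the hydroxyl group in particular, since no other group on that saturated ring carbon, such as methoxy, fluoro or an amine, appears among these compounds.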